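Positional Shift of Fluorine on a Pendant Aryl Ring

This account rests on a few compounds, and the source may have more. Where it says the series, first, only, none or still open, it means among the compounds named here.

Of the compounds shown here, two of a shared core have been measured in an ADME assay on microsomes from liver (Homo sapiens) for metabolic stability, tested at 2.5 uM; a higher number here means faster removal of the compound, a lower number slower removal. Compound 1 `O=S(=O)(c1ccc(F)c(Cl)c1)c1cnc2c(F)cccc2c1-c1ccc(F)cc1` gives 0.19 mL/min in this assay. Compound 2 `N#Cc1cccc(S(=O)(=O)c2cnc3c(F)cccc3c2-c2cccc(F)c2)c1` gives 0.34 mL/min in this assay, the higher of the two numbers, though compound 1 sits only a little below it, within the scatter of the method, so no order between them can be claimed. Compound 3 `N#Cc1cccc(S(=O)(=O)c2cnc3c(F)cccc3c2-c2ccc(F)cc2)c1` has not yet been measured. Compared with compound 2 it carries the same atoms joined differently: 4-fluorophenyl in place of 3-fluorophenyl on an aromatic carbon. The group that leaves and the group that enters are alike in size and count; only the fluorine sits at another ring position. Within the data shown here, with no measured pair showing this exact change, the step is expected to be small, a 1.2-fold lower number from compound 2 to compound 3 (0.08 log units; within the scatter), with no clear direction beyond the scatter. Compound 3 is therefore estimated at 0.28 mL/min in this assay, within the range 0.14 mL/min to 0.55 mL/min.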

Compound 3, intrinsic clearance in a liver preparation (reported as CLH), per the amount of preparation that the assay uses: 0.19 mL/min
Beside the measured number, compound 3's estimate is 1.5-fold (0.17 log units) above it; the measured number falls inside the stated range.
By their numbers in this assay, from the lowest: compounds 1, 3 and 2 (each within the scatter of the next).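

In this assay, 4-fluorophenyl in place of 3-fluorophenyl on this aromatic carbon gives a 1.8-fold lower number from compound 2 to compound 3 (0.25 log units; within the scatter), so this shift of the fluorine leaves the reading within the scatter of the method. On the sulfonyl sulfur, 3-cyanophenyl in place of 3-chloro-4-fluorophenyl gives no change at the digits printed from compound 1 to compound 3 (within the scatter), a comparison in one place that compound 1 and compound 2, which differ in two places, could not offer. Nothing is at hand that bears on what lies behind either step.

The compounds shown carry only a fluorophenyl on this aromatic carbon, so they leave open how the number would respond to an amine or a carboxylic acid at that place. Going by these compounds, whether the fluorine shift reads the same with 3-chloro-4-fluorophenyl on the sulfonyl sulfur also stays open.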